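The compounds below may be only part of what the source reports. "The series", "measured", "known", "first", "only" and "open" are said of these compounds alone.

Measured compounds:
compound 1, `O=C1C(NC2CCCC2)=CC(=O)c2c1nc1n2[C@H]2OC[C@@H](O)[C@H]2OC1`, which in a functional assay on ECa-109 cells for inhibition, with ECa-109 cell line (Homo sapiens) as the target, read by sulforhodamine B assay (on this read-out higher numbers stand for weaker inhibition and lower numbers for stronger inhibition), gives > 16000 nM, a limit of the assay;
compound 2, `CCc1ccc(NC2=CC(=O)c3nc4n(c3C2=O)[C@H]2OC[C@@H](O)[C@H]2OC4)cc1`, which in this assay gives 3080 nM.

Going by the values given here, compound 2 holds the only plain number in this assay. Among the compounds with values here, no step between two measured compounds is available to guide the change at hand. Compound 3, `O=C1C=C(Nc2ccc(I)cc2)C(=O)c2c1nc1n2[C@H]2OC[C@@H](O)[C@H]2OC1`, differs from compound 2 by iodo in place of ethyl on an aromatic carbon. Within the data shown here, with no measured step to draw on, compound 3 is expected to sit close to compound 2, the step of a 1.1-fold lower number from compound 2 to compound 3 (0.06 log units; within the scatter) staying within the usual scatter. Compound 3 is thus estimated at 2700 nM, between 1000 nM and 7500 nM.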

Compound 3, half-maximal inhibitory concentration: 2300 nM
The estimate for compound 3 lay 1.2-fold (0.07 log units) above the measured number, within the range that was stated.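

In this assay, iodo in place of ethyl on the aromatic carbon para to a large group gives a 1.3-fold lower number from compound 2 to compound 3 (0.13 log units; within the scatter) on the shared core. This is the first step shown at this position, and it shows that 4-iodophenyl and 4-ethylphenyl cannot be told apart here. Nothing at hand bears on a cause for this closeness. As far as these compounds go, whether an amine, a carboxylic acid or a longer chain at this place would move the number beyond the scatter stays open. So does the effect of a methoxy group there.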